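The source may report more compounds than this note shows. Statements on the series, on what has been measured and on what is new or still open speak of the compounds shown alone.

All three measured compounds share one core and differ only in the group on the urea-type nitrogen. Compound 1 `C=C[C@]1(C)C[C@@H](OC(=O)CNC(=O)Nc2ccccc2Br)[C@]2(C)[C@H](C)CC[C@]3(CCC(=O)[C@H]32)[C@@H](C)[C@@H]1O` carries a 2-bromophenyl there. In a functional assay on U-87MG ATCC cells for inhibition, with U-87 MG (Homo sapiens) as the target, read by MTT assay, with a stated time of 72 h (a higher number here means a weaker inhibitor, a lower number a stronger inhibitor), compound 1 reaches only a limit, > 10000 nM. Compound 2 `C=C[C@]1(C)C[C@@H](OC(=O)CNC(=O)NC(=O)c2ccc(Br)cc2)[C@]2(C)[C@H](C)CC[C@]3(CCC(=O)[C@H]32)[C@@H](C)[C@@H]1O` carries a (4-bromophenyl)carbonyl instead, and in this assay compound 2 also reaches only a limit, > 10000 nM. Compound 3 `C=C[C@]1(C)C[C@@H](OC(=O)CNC(=O)NC(=O)c2cccc(F)c2)[C@]2(C)[C@H](C)CC[C@]3(CCC(=O)[C@H]32)[C@@H](C)[C@@H]1O` carries a (3-fluorophenyl)carbonyl, and in this assay compound 3 likewise stops at a limit, > 10000 nM. The steps a step that the two limits leave unreadable from compound 1 to compound 2, a step that the two limits leave unreadable from compound 1 to compound 3 and a step that the two limits leave unreadable from compound 2 to compound 3 therefore have no readable size, all three values resting at the limit of > 10000 nM in this assay, at which 3 of the 3 values shown sit. Compound 4 `C=C[C@]1(C)C[C@@H](OC(=O)CNC(=O)Nc2ccc(F)cc2)[C@]2(C)[C@H](C)CC[C@]3(CCC(=O)[C@H]32)[C@@H](C)[C@@H]1O` has not yet been measured; it differs from compound 3 by 4-fluorophenyl in place of (3-fluorophenyl)carbonyl on an amide-type nitrogen. Among the measured compounds shown here, compound 1, which also carries a plain aryl on that nitrogen, sits at the same limit, so no measured step gives a direction for this change. Compound 4 is therefore expected to stay weak, with an estimated 15000 nM, between 4000 nM and 60000 nM. The expected step is a step that the limit leaves unreadable from compound 3 to compound 4.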

Compound 4, half-maximal inhibitory concentration: > 10000 nM
Compound 4 was reported as a limit; the forecaster's own chance of this, stated with the estimate: 75%; the middle value is on the limit's open side.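

Compound 4 reaches only a limit, > 10000 nM, in this assay, so no step linking compound 4 to compound 1, compound 2 or compound 3 can be read: the limit of > 10000 nM in this assay, at which 4 of the 4 values shown sit.

What the compounds shown leave open is whether any group on that amide-type nitrogen gives a measurable value.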